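Swapping Two Fluorines for Fluorine and Methyl

The source may report more compounds than this note shows. Statements on the series, on what has been measured and on what is new or still open speak of the compounds shown alone.

Compound 1, `COc1cc(-n2cnc3ccc(-c4cccc(N)c4)cc32)cc(OC)c1OC`: 640 nM
Compound 2, `COc1cc(-n2cnc3ccc(-c4cc(F)ccc4F)cc32)cc(OC)c1OC`: 7940 nM
Compound 3, `COc1ccc(-c2ccc3ncn(-c4cc(OC)c(OC)c(OC)c4)c3c2)cc1`: a limit, > 10000 nM

In a functional assay on A549 cells (Homo sapiens) for antiproliferative activity, read by MTT assay, with a stated time of 72 h (a higher number here means a weaker inhibitor, a lower number a stronger inhibitor), compound 2 stands highest of the two numbers given, separated from its nearest neighbour by a 12-fold higher number from compound 1 to compound 2 (1.09 log units; beyond the scatter). Compound 3 reached only the limit (the limit of > 10000 nM in this assay, at which 1 of the 3 values shown sits). Compound 4, `COc1cc(-n2cnc3ccc(-c4ccc(C)cc4F)cc32)cc(OC)c1OC`, is not yet measured; its change is 2-fluoro-4-methylphenyl in place of 2,5-difluorophenyl on an aromatic carbon. Going by the values given here, the only measured step starting from compound 2 is an at least 1.2-fold higher number from compound 2 to compound 3 (0.10 log units; that floor lies within the scatter), whose floor lies within the scatter, and no measured step covers a methyl or a single fluorine. The step of a 1.0-fold higher number from compound 2 to compound 4 (0.00 log units; within the scatter) is therefore expected to stay within the scatter. For compound 4 the estimate is 8000 nM, with a range from 2500 nM to 25000 nM.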

Compound 4, half-maximal inhibitory concentration: > 10000 nM
Compound 4 was reported as a limit; the forecaster's own chance of this, stated with the estimate: 35%; middle value at least 1.2-fold (0.09 log units) from the limit.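

In this assay, compound 4 gives > 10000 nM, which is a limit and not a number. Putting 2-fluoro-4-methylphenyl in place of 2,5-difluorophenyl gives an at least 1.2-fold higher number from compound 2 to compound 4 (0.10 log units; that floor lies within the scatter), so this swap shows no readable change, whereas replacing 3-aminophenyl gives an at least 15-fold higher number from compound 1 to compound 4 (1.19 log units; beyond the scatter), making this the third ring without an amine to sit well above compound 1. The step from compound 3 to compound 4 cannot be read, since both values are limits: the limit of > 10000 nM in this assay, at which 2 of the 4 values shown sit.

Still open, from the compounds shown here alone, is whether a hydroxyl group or an amide in place of the amine would keep the lower number of compound 1.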